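Moving a methyl group on a piperazine side chain

The source may hold more compounds than are shown below. What is called first, only, known or untested is meant among the compounds shown, and "the series" means these compounds.

Values so far in a toxicity assay on L02 cells (Homo sapiens) for cytotoxicity, read by MTT assay, with a stated time of 72 h; on this read-out lower numbers stand for stronger inhibition and higher numbers for weaker inhibition
- compound 1 `CN(C)CCCCCn1c2c(c3ccccc31)C(=O)c1c[n+]([O-])c3ccccc3c1C2=O` gives 240 nM
- compound 2 `O=C1c2c[n+]([O-])c3ccccc3c2C(=O)c2c1c1ccccc1n2CCCCn1ccnc1` gives 150 nM
- compound 3 `O=C1c2c[n+]([O-])c3ccccc3c2C(=O)c2c1c1ccccc1n2CCCCN1CCNCC1` gives 1380 nM

Of these three, compound 3 has the highest number, so it is the weakest inhibitor in this small set. Compound 4 `CN1CCN(CCCn2c3c(c4ccccc42)C(=O)c2c[n+]([O-])c4ccccc4c2C3=O)CC1` has the same atoms as compound 3 joined differently, and the change reads 4-methylpiperazin-1-yl in place of (piperazin-1-yl)methyl on a saturated chain carbon, three bonds along the chain from an aromatic nitrogen in this way: 4-methylpiperazin-1-yl in place of (piperazin-1-yl)methyl on a saturated chain carbon, three bonds along the chain from an aromatic nitrogen.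

Going by the values given here, no measured step isolates this change. The nearest evidence comes from swaps of the end group on the chain. One is a 5.8-fold higher number from compound 1 to compound 3 (0.76 log units; beyond the scatter) and another is a 9.2-fold higher number from compound 2 to compound 3 (0.96 log units; beyond the scatter) and both lie beyond the scatter. The third is a 1.6-fold lower number from compound 1 to compound 2 (0.20 log units; within the scatter) and lies within it. Among the compounds with values here, compound 3 is the only measured compound with an unsubstituted piperazin-1-yl, and three compounds are too few to set a rule. Even so, compound 4 no longer carries that exact end group, so a modest move in this assay is expected toward compound 1 at 240 nM and compound 2 at 150 nM rather than a further rise. The expected change is a 2.3-fold lower number from compound 3 to compound 4 (0.36 log units; beyond the scatter) and it remains uncertain. For compound 4 the estimate is 600 nM with an expected range from 200 nM to 1800 nM on repeated measurement.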

Compound 4, half-maximal inhibitory concentration: 230 nM
Compound 4: the middle estimate sits 2.6-fold (0.42 log units) above what was measured; the range from low to high includes it.
By their numbers in this assay, from the lowest: compounds 2, 4 and 1 (each within the scatter of the next); then compound 3.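

Compound 3 and compound 4 have the same atoms joined differently, yet this assay shows a 6.0-fold lower number from compound 3 to compound 4 (0.78 log units; beyond the scatter) when 4-methylpiperazin-1-yl replaces (piperazin-1-yl)methyl, so the same atoms do not guarantee a similar result at this position on the chain. The change also brings compound 4 level with the other two compounds, with a 1.5-fold higher number from compound 2 to compound 4 (0.19 log units; within the scatter) and a 1.0-fold lower number from compound 1 to compound 4 (0.02 log units; within the scatter) both inside the scatter, which leaves compound 3 as the only one of the four set apart from the rest. Nothing measured here accounts for this difference.

The same change can also be read as 4-(piperazin-1-yl)butyl becoming 3-(4-methylpiperazin-1-yl)propyl, so a shorter chain and a methyl on the ring nitrogen arrive together, and the compounds shown cannot say which of the two matters, or whether both do. A compound with a 3-(piperazin-1-yl)propyl chain and another with a 4-(4-methylpiperazin-1-yl)butyl chain would pull these two parts apart, each changing only one of them relative to compound 3.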